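The source may hold more compounds than are shown below. What is called first, only, known or untested is meant among the compounds shown, and "the series" means these compounds.

Measured in an ADME assay on BJ cells (Homo sapiens) for cytotoxicity, with a stated time of 72 h (a lower number here means that less compound is needed, a higher number that more compound is needed for the effect), and reported only as limits:
- Compound 1 `O=C(Nc1cccc(-c2nc3ccccc3s2)c1)c1cc([N+](=O)[O-])ccc1Cl` gives > 27000 nM as a limit
- Compound 2 `COc1ccc(-c2nc3ccccc3s2)cc1NC(=O)c1cc([N+](=O)[O-])ccc1Cl` gives > 25000 nM as a limit
- Compound 3 `COc1ccc(-c2nc3ccccc3s2)cc1NC(=O)c1cc([N+](=O)[O-])c(N2CCC(C(=O)O)CC2)cc1Cl` gives > 25000 nM as a limit

Compound 2 stands at the limit of > 25000 nM in this assay, at which 2 of the 3 values shown sit, and has no number. Compound 1 stands at the limit of > 27000 nM in this assay, at which 1 of the 3 values shown sits, and likewise has no number.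

Compound 4 `O=C(Nc1cc(-c2nc3ccccc3s2)ccc1Cl)c1cc([N+](=O)[O-])ccc1Cl` differs from compound 2 at one place: chloro in place of methoxy on an aromatic carbon and so the chloro takes the aromatic carbon that holds the methoxy.

Going by the values given here, two measured steps bear on this change. The closer one is a step that the two limits leave unreadable from compound 1 to compound 2 at that same carbon. The other is a step that the two limits leave unreadable from compound 2 to compound 3 at a different carbon. Neither has a readable size, so neither gives a direction or a measured magnitude to carry over. None of the three compounds yields a number in this assay and that is the only pattern available.

No step beyond the usual scatter is therefore expected, and no direction is expected either. The expected change is a step that the limit leaves unreadable from compound 2 to compound 4 as an estimate resting on these unreadable steps. Compound 4 is estimated at 26000 nM with an expected range from 13000 nM to 50000 nM and a further limit is the likeliest report.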

Compound 4, half-maximal effective concentration: > 25000 nM
Compound 4: no number, only a limit; the forecaster's own chance of this, stated with the estimate: 85%; the middle value is on the limit's open side.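

In this assay compound 4 gives > 25000 nM, which is a limit and not a number. No new step can be read from compound 4 to either compound 2 or compound 1, as all three carry only limits. The compounds shown leave open whether chloro in place of methoxy or of hydrogen on that aromatic carbon changes the half-maximal effective concentration at all.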